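Carboxy for phenoxy on the shared core

The source may report more compounds than this note shows. Statements on the series, on what has been measured and on what is new or still open speak of the compounds shown alone.

Three compounds on the shared core have numbers in an assay on isolated protein for inhibition of 2-Hydroxyacid oxidase 2 (Homo sapiens), tested at 10 uM; on this read-out higher numbers stand for a stronger effect at the one concentration tested and lower numbers for a weaker effect. Compound 1 `Cc1n[nH]c(C(=O)O)c1Cc1ccc2ccccc2n1` gives 18%. Compound 2 `Cc1n[nH]c(C(=O)O)c1Cc1ccc(Oc2ccccc2)cc1` gives 43%. Compound 3 `Cc1n[nH]c(C(=O)O)c1Cc1cccc(-c2ccc(C(F)(F)F)cc2)c1` gives 30%. On these three numbers compound 2 stands highest: the nearest is compound 3, lower by a gap beyond the scatter, and the furthest is compound 1, lower by a gap also beyond the scatter. The three compounds differ from one another in more than one place, so no single step between measured compounds can be read off, and what any one change does to the read-out is not shown.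

Compound 4 `Cc1n[nH]c(C(=O)O)c1Cc1ccc(C(=O)O)cc1` has not yet been measured. Set against compound 2 the difference is carboxy in place of phenoxy on an aromatic carbon. For the measured compounds named here, no measured compound carries a carboxy on this ring, so the expectation rests on the three numbers alone. Compound 2 gives 43% with a phenoxy in place, and the compound without any such detached ring, compound 1, gives 18%; on that basis the step is expected to be downward and beyond the scatter, at a number 28 percentage points lower from compound 2 to compound 4 (beyond the scatter). Compound 4 is estimated at 15%, with a range from 0% to 35%.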

Compound 4, a percentage reported as inhibition, at one concentration (the size of the read-out at that concentration, not a potency): 22%
The estimate for compound 4 lay 7 percentage points below the measured number, within the range that was stated.
By their numbers in this assay, from the lowest: compounds 1, 4 and 3 (each within the scatter of the next, the first and the last beyond it); then compound 2.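

For the compounds shown here, compound 4 gives the first step that can be read at one place: on an aromatic carbon para to a large group, carboxy in place of phenoxy gives a number 21 percentage points lower from compound 2 to compound 4 (beyond the scatter) in this assay. Going by these compounds alone, the read-out at the single concentration tested therefore depends on the group at this position, which the earlier compounds, differing in more than one place, could not show. No measurement shown here explains the step.

The change removes phenoxy, with its six-membered aromatic ring of carbon only and 7 heavy atoms, and brings in carboxy, with no ring and 3 heavy atoms, so this one step cannot separate the loss of the ring from the entry of the carboxy. On these data alone, a methoxy, a benzyloxy or an amine on the same aromatic carbon would bear on that question, and whether any group there exceeds the phenoxy of compound 2 at 43% remains open.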